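The source may hold more compounds than are shown below. What is called first, only, known or untested is meant among the compounds shown, and "the series" means these compounds.

Measured in an ADME assay on BHK-21 cells (Mesocricetus auratus) for cytotoxicity, read by MTT assay; on this read-out lower numbers stand for higher toxicity in this test and higher numbers for lower toxicity in this test:
- compound 1 `C/C(=N\NC(N)=O)c1ccc2[nH]c(-c3ccccc3)nc2c1`: > 100000 nM, a limit of the assay
- compound 2 `C/C(=N\NC(N)=O)c1ccc2[nH]c(-c3ccc(Cl)cc3)nc2c1`: > 100000 nM, also a limit of the assay
- compound 3 `CC(=O)c1ccc2[nH]c(-c3ccoc3)nc2c1`: 98000 nM

Compound 3 holds the only actual number among these, 98000 nM. Compound 4 `C/C(=N\NC(N)=O)c1ccc2[nH]c(-c3ccoc3)nc2c1` swaps its acetyl for a larger group: a group of 7 heavy atoms (3 carbon, 3 nitrogen, 1 oxygen; no ring) in place of a group of 3 heavy atoms (2 carbon, 1 oxygen; no ring), on an aromatic carbon. That group already sits on compound 1 and compound 2, and both stand at the limit of > 100000 nM in this assay, at which 2 of the 3 values shown sit. Going by the values given here, the one measured step, a step that the two limits leave unreadable from compound 1 to compound 2, concerns a chloro swap and gives no size to borrow. No change beyond the scatter is therefore expected in this assay, and the expected step is a 1.2-fold higher number from compound 3 to compound 4 (0.09 log units; within the scatter). The estimate for compound 4 is 120000 nM, with an expected range of 60000 nM to 240000 nM.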

Compound 4, half-maximal cytotoxic concentration: > 100000 nM
Compound 4 was reported as a limit; the forecaster's own chance of this, stated with the estimate: 75%; the middle value does not contradict the limit.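

Replacing acetyl with the larger group on this aromatic carbon gives, in this assay, an at least 1.0-fold higher number from compound 3 to compound 4 (0.00 log units; that floor lies within the scatter). Going by these compounds alone, this change, which the earlier compounds did not isolate, therefore shows no drop in the number on the core carrying furan-3-yl. Compound 4 joins compound 1 and compound 2 at a limit, and the steps among these three cannot be read: the limit of > 100000 nM in this assay, at which 3 of the 4 values shown sit.

Going by these compounds, whether an amine or a carboxylic acid on this aromatic carbon would give a lower number remains open.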